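Swapping the Hydrazone Aryl Group: Dimethyl to Methylsulfanyl

The source may report more compounds than this note shows. Statements on the series, on what has been measured and on what is new or still open speak of the compounds shown alone.

Of the compounds shown here, three sharing one core have been measured in a functional assay on A549 cells (Homo sapiens) for antiproliferative activity, read by MTT assay; a lower number here means a stronger inhibitor, a higher number a weaker inhibitor. Compound 1 `Cn1c(=O)c(=O)n(C2CCCC2)c2nc(N/N=C/c3ccc(O)cc3)ncc21` carries a 4-hydroxyphenyl group on the hydrazone carbon. In this assay compound 1 gives > 100000 nM, which is a limit of the assay rather than a number (the limit of > 100000 nM in this assay, at which 1 of the 3 values shown sits). Compound 2 `Cn1c(=O)c(=O)n(C2CCCC2)c2nc(N/N=C/c3ccc(O)c(F)c3)ncc21` adds fluorine to that ring and gives 97800 nM; the step of an at least 1.0-fold lower number from compound 1 to compound 2 (0.00 log units; that floor lies within the scatter) adds nothing beyond the scatter. Compound 3 `Cc1ccc(/C=N/Nc2ncc3c(n2)n(C2CCCC2)c(=O)c(=O)n3C)cc1C` replaces the hydroxyphenyl with 3,4-dimethylphenyl and gives 30200 nM, the lowest of the two real numbers; the steps of an at least 3.3-fold lower number from compound 1 to compound 3 (0.51 log units; beyond the scatter) and a 3.2-fold lower number from compound 2 to compound 3 (0.51 log units; beyond the scatter) both lower the number beyond the scatter.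

Compound 4 `CSc1ccc(/C=N/Nc2ncc3c(n2)n(C2CCCC2)c(=O)c(=O)n3C)cc1` changes that ring again: 4-(methylsulfanyl)phenyl in place of 3,4-dimethylphenyl on a carbon with a double bond to nitrogen. The measured steps that bear on this are those from the hydroxy-bearing rings to the dimethyl ring, each of modest size. Since compound 4 keeps a ring without a hydroxy group, the expectation is a step of a 1.0-fold lower number from compound 3 to compound 4 (0.00 log units; within the scatter) that stays within the scatter or drifts only slightly, in either direction. Compound 4 is therefore estimated at 30000 nM in this assay, with a plausible range from 10000 nM to 90000 nM.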

Compound 4, half-maximal inhibitory concentration: 14100 nM
Estimate against measurement, compound 4: 2.1-fold (0.33 log units) above; measured number inside the range.
By their numbers in this assay, from the lowest: compound 4; then compound 3; then compound 2. At a limit, above all of these: compound 1.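

The earlier compounds shown here showed the number falling only when a hydroxy-bearing ring gave way to one without a hydroxy group, whereas here both rings lack that group and the value still moves in this assay: a 2.1-fold lower number from compound 3 to compound 4 (0.33 log units; beyond the scatter). So the hydrazone carbon remains sensitive to the aryl group even after the hydroxy is gone, and the 4-(methylsulfanyl)phenyl ring gives the lowest number of the compounds with real values, with larger steps against the hydroxy-bearing rings: a 6.9-fold lower number from compound 2 to compound 4 (0.84 log units; beyond the scatter), and an at least 7.0-fold lower number from compound 1 to compound 4 (0.85 log units; beyond the scatter), the latter being a direct exchange of hydroxy for methylsulfanyl on an aromatic carbon. That last step is only a floor, as the entry for compound 1 is a limit and not a number: the limit of > 100000 nM in this assay, at which 1 of the 4 values shown sits.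

The ring change from compound 3 to compound 4 alters two things at once, the sulfur-bearing group and the loss of a methyl group, and these values cannot separate the two or explain the drop. On these data alone, how a methoxy group, a longer ethylsulfanyl chain or an amine would fare on that ring remains open, as does whether the number can fall much further in this assay.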